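Chloro in Place of Methoxy on the Aniline Ring

The compounds below may be only part of what the source reports. "The series", "measured", "known", "first", "only" and "open" are said of these compounds alone.

Measured so far:
Compound 1, `Cc1ccc(NC2=CC(=O)c3nc4n(c3C2=O)[C@H]2OC[C@@H](O)[C@H]2OC4)cc1`: 1420 nM
Compound 2, `COc1cccc(NC2=CC(=O)c3c(nc4n3[C@H]3OC[C@@H](O)[C@H]3OC4)C2=O)c1`: 1790 nM
Compound 3, `Cc1ccc(NC2=CC(=O)c3nc4n(c3C2=O)[C@H]2OC[C@@H](O)[C@H]2OC4)cc1C`: 860 nM

All three were tested in a functional assay on MGC-803 cells (Homo sapiens) for inhibition, read by sulforhodamine B assay; a higher number here means a weaker inhibitor, a lower number a stronger inhibitor. Compound 2 gives the highest of the three numbers; its nearest neighbour is compound 1, whose value lies within the usual scatter of it, and its furthest is compound 3, whose value lies beyond the scatter. For the measured compounds named here, the only single-point step among the measured compounds is a 1.7-fold lower number from compound 1 to compound 3 (0.22 log units; within the scatter), and that step stays within the scatter.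

The unmeasured compound 4, `O=C1C(Nc2cccc(Cl)c2)=CC(=O)c2c1nc1n2[C@H]2OC[C@@H](O)[C@H]2OC1`, differs from compound 2 by chloro in place of methoxy on an aromatic carbon. Going by the values given here, no measured step swaps one substituent for another at the same position, so the measured step gives only indirect guidance: it shows that a small change on this ring moved the number by little. The three measured values all fall inside a narrow band, which argues for a similarly modest effect here.

Compound 4 is therefore expected to land close to the measured compounds, at about 1300 nM, with a likely range from 600 nM to 3000 nM. The step of a 1.4-fold lower number from compound 2 to compound 4 (0.14 log units; within the scatter) is estimated to stay within the scatter, in no firm direction.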

Compound 4, half-maximal inhibitory concentration: 1530 nM
Compound 4: the middle estimate sits 1.2-fold (0.07 log units) below what was measured; the measured number falls inside the stated range.
By their numbers in this assay, from the lowest: compounds 3, 1, 4 and 2 (each within the scatter of the next, the first and the last beyond it).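

In this assay, for the compounds shown here, the change reads a 1.2-fold lower number from compound 2 to compound 4 (0.07 log units; within the scatter) and is the first direct swap of one substituent for another at a single place on this ring, since 3-methoxyphenyl gives way to 3-chlorophenyl with the rest of the molecule unchanged. The earlier step from compound 1 to compound 3 only added a methyl group, whereas this one takes away methoxy, with its hydrogen-bond acceptor, and puts in chloro, which has fewer heavy atoms and no such acceptor, and the number still stays within the scatter. The data shown offer no measurement that explains this flat result.

Going by these compounds alone, whether this place tolerates any group equally remains open, as chloro and methoxy are only two examples, and a group such as an amine, a carboxylic acid or a longer chain on the same aromatic carbon could give a quite different number. The compounds shown also contain no pair that moves one group from this place to another place on the ring, so the importance of the position itself remains unsettled.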